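Longer Acyl Chain on the Amide: Compound 2 to Compound 3

The compounds below may be only part of what the source reports. "The series", "measured", "known", "first", "only" and "open" are said of these compounds alone.

Two amides on a shared core have been measured in a functional assay on A549 cells (Homo sapiens) for cytotoxicity, read by sulforhodamine B assay, with a stated time of 72 h; a higher number here means a weaker inhibitor, a lower number a stronger inhibitor. Compound 1 `CCCCCCC(=O)Nc1ccn([C@@H]2CO[C@H](CO)O2)c(=O)n1` gives 1040 nM, while compound 2 `CCCCCCCCCCCCCCCC(=O)Nc1ccn([C@@H]2CO[C@H](CO)O2)c(=O)n1` gives 4 nM. Among the compounds with values here, compound 2 thus stands at the lowest number of the two, and the single step between them, a 260-fold lower number from compound 1 to compound 2 (2.41 log units; beyond the scatter), is large. Compound 3 `CCCCCCCCCCCCCCCCCC(=O)Nc1ccn([C@@H]2CO[C@H](CO)O2)c(=O)n1` carries the change (ethyl in place of hydrogen on a saturated chain carbon, ten or more bonds along the chain from a carbonyl carbon), a further extension of the same chain that was lengthened between compound 1 and compound 2. Within the data shown here, that one step is the only evidence that bears on it, and it points toward lower numbers with added chain length; nothing in the data tells where that trend levels off. Compound 3 is therefore expected to show a step of a 1.3-fold lower number from compound 2 to compound 3 (0.12 log units; within the scatter) in this assay, modest and in the lower direction. Compound 3 is estimated at 3 nM, with a range from 1 nM to 12 nM.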

Compound 3, half-maximal inhibitory concentration: 25 nM
Compound 3: middle estimate off by 8.3-fold (0.92 log units), on the low side; the whole stated range lies below it.
By their numbers in this assay, from the lowest: compound 2; then compound 3; then compound 1.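

In this assay, the added ethyl reverses the direction seen so far (a 6.3-fold higher number from compound 2 to compound 3 (0.80 log units; beyond the scatter)), so lengthening the chain does not keep lowering the number. Compound 3 still retains much of the gain over the shorter chain (a 42-fold lower number from compound 1 to compound 3 (1.62 log units; beyond the scatter)), which places compound 2 lowest of the three and shows a fall followed by a rise across these compounds. Nothing available here accounts for this rise.

It remains open whether a chain of a length not shown here, shorter or longer than that of compound 2, would give a lower number, and how much further a longer chain than that of compound 3 would raise it. An amine or a carboxylic acid at the far end of the chain is equally unresolved.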